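The source may report more compounds than this note shows. Statements on the series, on what has been measured and on what is new or still open speak of the compounds shown alone.

Measured compounds:
- compound 1, `Cc1cc(-c2nnc3n2CCCCC3)c(C)n1-c1ccc([N+](=O)[O-])cc1`: 108 nM 
- compound 2, `COc1cccc(-n2cnc3cc(C(=O)N4CCCCC4)ccc32)c1`: 19 nM 

In an assay on isolated protein for inhibition of 15-hydroxyprostaglandin dehydrogenase [NAD(+)] (Homo sapiens), read by fluorescence, with a stated time of 15 min (on this read-out lower numbers stand for stronger inhibition and higher numbers for weaker inhibition), compound 2 gives the lower of the two numbers available, with compound 1 showing a higher number, and that gap lies beyond the scatter. Among the compounds with values here, no step between compounds that differ in one place is available, so the two values only show that the two scaffolds differ in this assay.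

Compound 3, `CC(C)(C)c1cccc(-n2cnc3cc(C(=O)N4CCCCC4)ccc32)c1`, has not yet been measured. It differs from compound 2 by tert-butyl in place of methoxy on an aromatic carbon. Within the data shown here, nothing among the measured compounds tests this exchange, so the expectation rests on compound 2 alone. The step is expected to be small, probably a slight move toward a higher number, but not clearly beyond the scatter: the step from compound 2 to compound 3 in this assay is estimated as a 1.6-fold higher number from compound 2 to compound 3 (0.20 log units; within the scatter). For compound 3 the expected value is 30 nM, with a range from 8 nM to 120 nM.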

Compound 3, half-maximal inhibitory concentration: 171 nM
Compound 3: the middle estimate sits 5.7-fold (0.76 log units) below what was measured; the whole stated range lies below it.
By their numbers in this assay, from the lowest: compound 2; then compounds 1 and 3 (each within the scatter of the next).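

Within the shared core, this carbon of the six-membered aromatic ring, meta to a large group, is sensitive to its substituent in this assay: tert-butyl in place of methoxy gives a 9.0-fold higher number from compound 2 to compound 3 (0.95 log units; beyond the scatter), with the rest of the structure unchanged. Within the data shown here, this is the first comparison that isolates one place, whereas the earlier values only set two scaffolds apart. Nothing available explains the size of this step.

Among these compounds, with only two groups at this carbon, the step does not separate the loss of the methoxy oxygen from the gain of the extra carbons. Ethoxy, methyl, a hydroxyl or a dimethylamino group at the same carbon would show which of these changes tracks with the number in this assay.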